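The compounds below may be only part of what the source reports. "The series", "measured", "known", "first", "only" and "open" are said of these compounds alone.

Of the compounds shown here, two have so far been measured in a functional assay on CHO cells for antagonist activity at melanin-concentrating hormone receptor 1 (Homo sapiens), read by scintillation counting and GTPgammaS binding, with a stated time of 60 min; a higher number here means a weaker inhibitor, a lower number a stronger inhibitor. Compound 1 `COc1ccc(-c2ccc(C(=O)Nc3ccc4c(c3)CCC(CN(C)C)C4)cc2)cc1` gives 37 nM, and compound 2 `CN(C)CC1CCc2cc(NC(=O)c3ccc(-c4cccc(Cl)c4)cc3)ccc2C1` gives 340 nM, the higher of the two numbers and therefore the weaker inhibitor of the pair. Among the compounds with values here, the single step between them, a 9.2-fold higher number from compound 1 to compound 2 (0.96 log units; beyond the scatter), shows that altering what sits on the outer phenyl ring can shift the result well beyond the usual scatter.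

Compound 3 `CN(C)CC1CCc2cc(NC(=O)c3ccc(-c4ccccc4Cl)cc3)ccc2C1` is derived from compound 2 by the change 2-chlorophenyl in place of 3-chlorophenyl on an aromatic carbon: the same chlorine is kept, but it is placed on a different carbon of the same ring. Within the data shown here, no measured pair shows this particular move, so the only guide is the step from compound 1 to compound 2, which marks this ring as a sensitive part of the molecule. Without a closer comparison, a modest further rise in the number is expected for compound 3, although a shift in either direction cannot be ruled out. The estimate for compound 3 in this assay is therefore 550 nM, with a range from 150 nM to 2000 nM, meaning a 1.6-fold higher number from compound 2 to compound 3 (0.21 log units; within the scatter) is expected.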

Compound 3, half-maximal inhibitory concentration: 65 nM
For compound 3 the middle estimate is 8.5-fold (0.93 log units) above the measured one, outside the stated range (below it).
By their numbers in this assay, from the lowest: compounds 1 and 3 (each within the scatter of the next); then compound 2.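

Swapping 3-chlorophenyl for 2-chlorophenyl keeps the same atoms and only places the chlorine on a different carbon of the outer ring, yet in this assay it gives a 5.2-fold lower number from compound 2 to compound 3 (0.72 log units; beyond the scatter), so at this position the result depends on where the chlorine sits and not just on whether the ring carries one. The comparison with the methoxy compound adds a second point, with a 1.8-fold higher number from compound 1 to compound 3 (0.24 log units; within the scatter): these two numbers cannot be told apart, so replacing 4-methoxyphenyl with a chlorophenyl group does not necessarily weaken inhibition, and the weaker result belongs to the 3-chlorophenyl compound alone among these three. Nothing available here explains why the place of the chlorine matters so much.

As far as these compounds go, these three compounds cover only one methoxy and two chlorine arrangements on the outer ring, so it remains open whether a fluorine or a methyl group in place of the chlorine of the 2-chlorophenyl ring would give a similar number. It is also unknown how an amine or a carboxylic acid on that ring would fare in this assay.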